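This account rests on a few compounds, and the source may have more. Where it says the series, first, only, none or still open, it means among the compounds named here.

Three compounds from one series have been examined for cytotoxicity in an ADME assay on THP-1 cells (Homo sapiens) for cytotoxicity, read by flow cytometry, with a stated time of 72 h (on this read-out higher numbers stand for weaker inhibition and lower numbers for stronger inhibition), and a fourth, closely related one, has not. Compound 1 `N/C(=N\O)c1ccc(C2=C(S(=O)(=O)c3ccc(Nc4cccc(/C(N)=N/O)c4)cc3)CC(c3ccccc3)(c3ccccc3)O2)cc1` and compound 3 `N/C(=N\O)c1ccc(C2=C(S(=O)(=O)c3ccc(Nc4ccccc4/C(N)=N/O)cc3)CC(c3ccccc3)(c3ccccc3)O2)cc1` share a core and differ only at a single point: a group of 10 heavy atoms (7 carbon, 2 nitrogen, 1 oxygen; one six-membered aromatic ring of carbon only) in place of a group of 10 heavy atoms (7 carbon, 2 nitrogen, 1 oxygen; one six-membered aromatic ring of carbon only), on a nitrogen on an aromatic ring. Compound 2 `N/C(=N\O)c1ccc(S(=O)(=O)C2=C(c3ccc(Nc4cccc(/C(N)=N/O)c4)cc3)OC(c3ccccc3)(c3ccccc3)C2)cc1` has the same atoms as compound 1 joined differently; the difference between the two cores is not broken down here. Compound 4 `N/C(=N\O)c1ccc(S(=O)(=O)C2=C(c3ccc(Nc4ccccc4/C(N)=N/O)cc3)OC(c3ccccc3)(c3ccccc3)C2)cc1` stands to compound 2 exactly as compound 3 stands to compound 1, that is, (a group of 10 heavy atoms (7 carbon, 2 nitrogen, 1 oxygen; one six-membered aromatic ring of carbon only) in place of a group of 10 heavy atoms (7 carbon, 2 nitrogen, 1 oxygen; one six-membered aromatic ring of carbon only), on a nitrogen on an aromatic ring). The place of the change is described in the same words for both pairs, so it is the same change.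

For compound 1, the result in this assay is a limit of the assay, > 50000 nM, not a number. For compound 3 the result is likewise a limit, > 50000 nM. Because both sit at the limit of > 50000 nM in this assay, at which 2 of the 3 values shown sit, the step from one to the other cannot be read: a step that the two limits leave unreadable from compound 1 to compound 3. Compound 2 is the only one of the three to give a number in this assay, 48100 nM. That number is not far from where the results of compound 1 and compound 3 sit.

What this change does to cytotoxicity is therefore unknown from compound 1 and compound 3. Since compound 2 already lies near the limit, compound 4 is expected to show a step of a 1.0-fold higher number from compound 2 to compound 4 (0.02 log units; within the scatter), which is to say essentially none, with a good chance that only a limit is reported. On that basis compound 4 is estimated at 50000 nM, within the range 25000 nM to 100000 nM.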

Compound 4, half-maximal inhibitory concentration: 47800 nM
The estimate for compound 4 lay 1.0-fold (0.02 log units) above the measured number; measured number inside the range.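

In this assay, the change on a nitrogen on an aromatic ring gives a 1.0-fold lower number from compound 2 to compound 4 (0.00 log units; within the scatter), so the two groups cannot be told apart on the core of compound 2, even though they differ in structure. The matching step from compound 1 to compound 3 cannot be read, because both results are limits of the assay and not numbers: the limit of > 50000 nM in this assay, at which 2 of the 4 values shown sit. For the compounds shown here, the series therefore offers only one readable pair, which shows what the change does on one core but does not show that the result carries over to the other core, or that the change would matter as little in a compound with a much lower number.

The compounds shown leave open what a different group on that same nitrogen, such as one carrying a carboxylic acid or an amine, would do in this assay, and whether any such group would move the result clearly away from the limit. They also leave open whether compound 1 and compound 3 truly match each other, since two limits give no number to compare.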